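A few compounds are considered here, and "the series" means these few. Any claim that something is new, unique, unknown or untested is made for them only; others in the source may bear on it.

Compound 1 `O=Cc1cn(Cc2ccc(Cl)cc2)c2cc(F)ccc12`: > 31600 nM (a limit)
Compound 2 `OCc1cc2cc(F)ccc2n1Cc1ccc(Cl)cc1`: 17400 nM
Compound 3 `OCc1cn(Cc2cccc(F)c2)c2ccccc12`: > 31600 nM (a limit)

In an ADME assay on T29 cells (Homo sapiens) for cytotoxicity, read by sulforhodamine B assay, with a stated time of 3 days (on this read-out lower numbers stand for stronger inhibition and higher numbers for weaker inhibition), compound 3 gives > 31600 nM, which is a limit and not a number. Most of the series sits there: the limit of > 31600 nM in this assay, at which 2 of the 3 values shown sit. Compound 4 `OCc1cn(Cc2cccc(Br)c2)c2ccccc12` has bromo in place of fluoro on an aromatic carbon, meta to a large group: bromo in place of fluoro on an aromatic carbon. Among the compounds with values here, no measured step between compounds that differ in one place is available. Within the data shown here, compound 2 at 17400 nM is the only number to lean on, so a small step towards stronger inhibition is expected, or none beyond the scatter. The estimated change is small: an at least 1.1-fold lower number from compound 3 to compound 4 (0.05 log units; that floor lies within the scatter). For compound 4 the expected value is 28000 nM, with an estimated range from 11000 nM to 50000 nM.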

Compound 4, half-maximal inhibitory concentration: > 31600 nM
Compound 4 was reported as a limit; the forecaster's own chance of this, stated with the estimate: 55%; middle value at least 1.1-fold (0.05 log units) away from the limit.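

Compound 3 and compound 4 both give limits and not numbers, so no step can be read for bromo in place of fluoro. From the compounds shown here alone, whether this exchange changes cytotoxicity at all, and by how much, stays open.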